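The compounds below may be only part of what the source reports. "The series", "measured", "known", "first", "only" and "open" are said of these compounds alone.

In a functional assay on K562 cells (Homo sapiens) for antiproliferative activity, read by CellTiter-Glo, with a stated time of 72 h (on this read-out higher numbers stand for an effect only at larger amounts of compound and lower numbers for an effect already at smaller amounts), compound 3 `NS(=O)(=O)OC[C@H]1O[C@@H](n2cnc3c(NCc4cccs4)ncnc32)[C@H](O)[C@@H]1O` gives 114 nM and stands level with compound 1 `CCCCCCNc1ncnc2c1ncn2[C@@H]1O[C@H](COS(N)(=O)=O)[C@@H](O)[C@H]1O` at 160 nM within the scatter, as a 1.4-fold lower number from compound 1 to compound 3 (0.15 log units; within the scatter) shows. Compound 2 `CC(C)(C)CC(C)(C)Nc1ncnc2c1ncn2[C@@H]1O[C@H](COS(N)(=O)=O)[C@@H](O)[C@H]1O` reads > 1000 nM and this value is a limit of the assay. Compound 4 `NS(=O)(=O)OC[C@H]1O[C@@H](n2cnc3c(N4CCC5CCCCC5C4)ncnc32)[C@H](O)[C@@H]1O` keeps the shared core but loses the ((thiophen-2-yl)methyl)amino group of compound 3 on an aromatic carbon, the counted change being a group of 10 heavy atoms (9 carbon, 1 nitrogen; one six-membered non-aromatic ring of carbon only, one six-membered non-aromatic ring with 1 hetero atom) in place of a group of 7 heavy atoms (5 carbon, 1 nitrogen, 1 sulfur; one five-membered aromatic ring with 1 hetero atom), on an aromatic carbon in this exchange. Among the measured compounds shown here, three measured steps bear on it, all at the same place. Hexyl and (thiophen-2-yl)methyl stay within the scatter in a 1.4-fold lower number from compound 1 to compound 3 (0.15 log units; within the scatter) but compound 2, with 1,1,3,3-tetramethylbutyl, stands apart in an at least 6.2-fold higher number from compound 1 to compound 2 (0.79 log units; beyond the scatter) and in an at least 8.7-fold lower number from compound 2 to compound 3 (0.94 log units; beyond the scatter) as beyond it. None of these compounds carries the entering group, so the guide is loose, but the steps around compound 2 point to a modest rise rather than none. The expected change is a 4.4-fold higher number from compound 3 to compound 4 (0.64 log units; beyond the scatter) in this assay. Compound 4 is estimated at 500 nM with an expected range from 150 nM to 1800 nM in the same read-out.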

Compound 4, half-maximal effective concentration: > 1000 nM
Compound 4 was reported as a limit; the forecaster's own chance of this, stated with the estimate: 30%; middle value at least 2.0-fold (0.30 log units) away from the limit.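

In this assay compound 4 gives > 1000 nM, which is a limit of the assay. On an aromatic carbon, the entering group with its two six-membered non-aromatic rings therefore gives up the level shared by the thiophene and hexyl compounds, with an at least 8.7-fold higher number from compound 3 to compound 4 (0.94 log units; beyond the scatter) and an at least 6.2-fold higher number from compound 1 to compound 4 (0.79 log units; beyond the scatter), so a ring-bearing group at this position does not by itself preserve that level. The entering group has 0 hydrogen-bond donors where ((thiophen-2-yl)methyl)amino has 1, but compound 2 reaches the same limit, so this count alone does not account for the loss.

The step between compound 2 and compound 4 cannot be read because both stand at the same limit: the limit of > 1000 nM in this assay, at which 2 of the 4 values shown sit. On these data alone, it remains open whether a piperidine, with a single ring, or a methylamino group at this position would stay level with compound 3.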